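The compounds below may be only part of what the source reports. "The series", "measured", "known", "first", "only" and "open" are said of these compounds alone.

Measured compounds:
compound 1 `CCCCCCCCNc1nc(SCc2ccc(C(F)(F)F)cc2)nc2ccccc12`: 22300 nM
compound 2 `O=[N+]([O-])c1cccc(Nc2nc(SCc3ccc(C(F)(F)F)cc3)nc3ccccc23)c1`: 31500 nM
compound 3 `FC(F)(F)c1ccc(CSc2nc(Nc3ccc(Cl)cc3)c3ccccc3n2)cc1`: 15100 nM

All three were tested in a functional assay on MDA-MB-231 cells (Homo sapiens) for cytotoxicity, read by MTT assay, with a stated time of 72 h; a higher number here means a weaker inhibitor, a lower number a stronger inhibitor. Compound 1 stands second highest of the three numbers; its nearest neighbour is compound 2, with a 1.4-fold higher number from compound 1 to compound 2 (0.15 log units; within the scatter), and its furthest is compound 3, with a 1.5-fold lower number from compound 1 to compound 3 (0.17 log units; within the scatter). Within the data shown here, the only step beyond the scatter is a 2.1-fold lower number from compound 2 to compound 3 (0.32 log units; beyond the scatter), a modest one between the two aryl groups.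

Compound 4 `CCOc1ccc(Nc2nc(SCc3ccc(C(F)(F)F)cc3)nc3ccccc23)cc1` differs from compound 1 in one place: 4-ethoxyphenyl in place of octyl on a nitrogen on an aromatic ring. Among the measured compounds shown here, two measured steps bear on this: both a 1.4-fold higher number from compound 1 to compound 2 (0.15 log units; within the scatter) and a 1.5-fold lower number from compound 1 to compound 3 (0.17 log units; within the scatter) put an aryl group in place of the octyl chain on the same nitrogen, and both stay within the scatter. Nothing among these three compounds singles out the 4-ethoxyphenyl group. In this assay compound 4 is therefore expected to sit close to compound 1, with a 1.2-fold lower number from compound 1 to compound 4 (0.09 log units; within the scatter) not beyond the scatter. The estimate for compound 4 is 18000 nM, with a range from 9000 nM to 40000 nM.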

Compound 4, half-maximal inhibitory concentration: 23000 nM
For compound 4 the middle estimate is 1.3-fold (0.11 log units) below the measured one; the measured number falls inside the stated range.
By their numbers in this assay, from the lowest: compounds 3, 1, 4 and 2 (each within the scatter of the next, the first and the last beyond it).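

In this assay, a third kind of group on this nitrogen, 4-ethoxyphenyl, leaves the number where the octyl chain had it, with a 1.0-fold higher number from compound 1 to compound 4 (0.01 log units; within the scatter). The ethoxy group in place of chloro on an aromatic carbon gives a 1.5-fold higher number from compound 3 to compound 4 (0.18 log units; within the scatter), and the 4-ethoxyphenyl group in place of 3-nitrophenyl gives a 1.4-fold lower number from compound 2 to compound 4 (0.14 log units; within the scatter), so compound 4 cannot be told apart from either aryl neighbour, even though those two neighbours differ modestly from each other. Nothing shown explains these small steps.

The compounds shown leave open whether any group on this nitrogen can move the number well beyond the scatter, such as a phenyl ring carrying a carboxylic acid or a primary amine, or a chain shorter than octyl. They also leave open what replacing the trifluoromethyl group would do.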